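Thiophen-3-yl swap on the amide-type nitrogen

The source may hold more compounds than are shown below. What is called first, only, known or untested is meant among the compounds shown, and "the series" means these compounds.

Values from a functional assay on U-937 cells (Homo sapiens), read by cAMP accumulation (on this read-out lower numbers stand for an effect already at smaller amounts and higher numbers for an effect only at larger amounts of compound), are these
- compound 1 `CCc1nn(-c2ccc(F)cc2)c2c1CCN(c1ccc(C)cc1)C2=O` gives 500 nM
- compound 2 `CCc1nn(C2CCCC2)c2c1CCN(c1ccccc1C)C2=O` gives 330 nM

Compound 2 stands within the scatter of compound 1, so the two values set no order. For the measured compounds named here, these compounds differ in more than one place, and no single-place step has been measured.

Compound 3 `CCc1nn(C2CCCC2)c2c1CCN(c1ccsc1)C2=O` is still unmeasured. It carries thiophen-3-yl in place of 2-methylphenyl on an amide-type nitrogen in a ring.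

Going by the values given here, with no measured step to guide it, the expectation rests only on the values of compound 1 (500 nM) and compound 2 (330 nM). Going by these compounds, no step beyond the scatter is expected, and the direction stays open. The estimated change is a 1.2-fold higher number from compound 2 to compound 3 (0.08 log units; within the scatter) and is expected to stay within the scatter. The estimate for compound 3 is 400 nM (expected range 120 nM to 1300 nM).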

Compound 3, half-maximal effective concentration: 36 nM
Compound 3: the middle estimate sits 11-fold (1.05 log units) above what was measured; the whole stated range lies above it.
By their numbers in this assay, from the lowest: compound 3; then compounds 2 and 1 (each within the scatter of the next).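

In this assay, the group on the amide-type nitrogen in a ring proves able to shift the read-out: thiophen-3-yl in place of 2-methylphenyl gives a 9.2-fold lower number from compound 2 to compound 3 (0.96 log units; beyond the scatter), with nothing else in the molecule changed. For the compounds shown here, this is the first single-place step, and the earlier pair, which differed in more than one place, could not show this. The entering group differs from the leaving one in ring size, heavy-atom count and its sulfur, and nothing available separates these features or accounts for the step.

Going by these compounds, it remains open whether the lower number is specific to thiophen-3-yl or would also appear with thiophen-2-yl, furan-3-yl or plain phenyl at this nitrogen. Also open, on these data alone, are the effect of an aminomethyl or carboxylic acid group on the thiophene and whether the step carries over to the core of compound 1.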